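Swapping the chain-borne group of compound 1 for 4-phenylphenyl

The source may hold more compounds than are shown below. What is called first, only, known or untested is meant among the compounds shown, and "the series" means these compounds.

Of the compounds shown here, three sharing one core have been tested in an ADME assay on cells (Peritoneal macrophage, Mus musculus, strain Balb/c) for cytotoxicity, read by resazurin assay, with a stated time of 72 h; on this read-out higher numbers stand for lower toxicity in this test and lower numbers for higher toxicity in this test. Compound 1 `CC1(Cc2cccc(/C(N)=N/O)c2)CC(S(=O)(=O)c2ccc(F)cc2)=C(c2ccc(/C(N)=N/O)cc2)O1` gives 50200 nM in this assay. Compound 2 `CC1(Cc2ccc([N+](=O)[O-])cc2)CC(S(=O)(=O)c2ccc(F)cc2)=C(c2ccc(/C(N)=N/O)cc2)O1` gives 97400 nM, and compound 3 `CC1(Cc2cccc([N+](=O)[O-])c2)CC(S(=O)(=O)c2ccc(F)cc2)=C(c2ccc(/C(N)=N/O)cc2)O1` gives 86600 nM. On these numbers compound 1 stands lowest of the three, yet the step of a 1.9-fold higher number from compound 1 to compound 2 (0.29 log units; within the scatter) and the step of a 1.7-fold higher number from compound 1 to compound 3 (0.24 log units; within the scatter) both fall within the usual scatter of this assay, so the three compounds are not distinguishable here.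

Compound 4 `CC1(Cc2ccc(-c3ccccc3)cc2)CC(S(=O)(=O)c2ccc(F)cc2)=C(c2ccc(/C(N)=N/O)cc2)O1` has not yet been measured. It differs from compound 1 in one place: a group of 12 heavy atoms (12 carbon; 2 six-membered aromatic rings of carbon only) in place of a group of 10 heavy atoms (7 carbon, 2 nitrogen, 1 oxygen; one six-membered aromatic ring of carbon only), on a saturated chain carbon bound to a saturated ring carbon. The two measured steps that bear on this change are those from compound 1 to compound 2 and from compound 1 to compound 3, which also exchange the group on that same chain carbon, and neither moved the number beyond the scatter. The entering 4-phenylphenyl is a larger group with no hydrogen-bond donors or acceptors, which is a different kind of exchange than the nitro replacements, so some uncertainty remains. Still, compound 4 is expected to show a step of a 1.3-fold higher number from compound 1 to compound 4 (0.11 log units; within the scatter) in this assay, not beyond the scatter, with an estimated value of 65000 nM and a range from 28000 nM to 150000 nM.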

Compound 4, half-maximal cytotoxic concentration: 33900 nM
Compound 4: the middle estimate sits 1.9-fold (0.28 log units) above what was measured; measured number inside the range.
By their numbers in this assay, from the lowest: compounds 4, 1, 3 and 2 (each within the scatter of the next, the first and the last beyond it).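

In this assay, the group on this saturated chain carbon now gives its first steps beyond the scatter: a 2.9-fold lower number from compound 2 to compound 4 (0.46 log units; beyond the scatter) with phenyl in place of nitro on an aromatic carbon, and a 2.6-fold lower number from compound 3 to compound 4 (0.41 log units; beyond the scatter) with 4-phenylphenyl in place of 3-nitrophenyl, both of them modest. Against the compound that carries the second amidoxime-bearing ring, however, the exchange gives only a 1.5-fold lower number from compound 1 to compound 4 (0.17 log units; within the scatter) and stays within the scatter, so compound 4 separates from the two nitro compounds but not from compound 1, and this position does not respond to every exchange in the same way. Nothing measured here explains why the two nitro compounds and compound 4 separate in this test.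

The compounds shown leave open whether the lower number goes with the second benzene ring itself or with the loss of the nitro group, a question that a plain phenyl on the same chain carbon could help to settle. They also leave open how a 4-aminophenyl or a 4-carboxyphenyl group would read at this place, and whether a single step of that kind would clear the scatter against compound 1.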